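The source may report more compounds than this note shows. Statements on the series, on what has been measured and on what is new or still open speak of the compounds shown alone.

Compound 1 `CCCC[C@H](NC(=O)OC(C)(C)C)C(=O)N[C@@H]1C[C@H](C(=O)NO)N(S(=O)(=O)c2ccc(OC)cc2)C1` gives 131 nM in an assay on isolated protein for inhibition of matrix metalloproteinase-9 (Homo sapiens), read by fluorescence; on this read-out lower numbers stand for stronger inhibition and higher numbers for weaker inhibition.
Compound 2 `COc1ccc(S(=O)(=O)N2C[C@H](NC(=O)[C@H](CCCN)NC(=O)OC(C)(C)C)C[C@@H]2C(=O)NO)cc1` gives 3420 nM in this assay.

Of these two numbers, compound 2 stands highest: the step of a 26-fold higher number from compound 1 to compound 2 (1.42 log units; beyond the scatter) marks it as the weaker inhibitor. Compound 3 `COc1ccc(S(=O)(=O)N2C[C@H](NC(=O)[C@H](CCCCN)NC(=O)OC(C)(C)C)C[C@@H]2C(=O)NO)cc1` carries the change (aminomethyl in place of amino on a saturated chain carbon, four bonds along the chain from an amide-type nitrogen and a carbonyl carbon). For the measured compounds named here, the one measured step, a 26-fold higher number from compound 1 to compound 2 (1.42 log units; beyond the scatter), concerns putting the amino in, not moving it outward, so it gives no direction for compound 3; the amino stays, only the chain grows. No step beyond the scatter is expected, a 1.6-fold lower number from compound 2 to compound 3 (0.19 log units; within the scatter). Compound 3 is therefore estimated at 2200 nM, within 600 nM to 8000 nM.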

Compound 3, half-maximal inhibitory concentration: 27 nM
Compound 3: the middle estimate sits 81-fold (1.91 log units) above what was measured, outside the stated range (below it).
By their numbers in this assay, from the lowest: compound 3; then compound 1; then compound 2.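

In this position on the chain, length counts as well as the presence of the amine: in this assay, aminomethyl in place of amino moves the number sharply down (a 130-fold lower number from compound 2 to compound 3 (2.10 log units; beyond the scatter)). The amino group is also not simply harmful, since amino in place of hydrogen, five bonds along the chain, lowers the number too (a 4.9-fold lower number from compound 1 to compound 3 (0.69 log units; beyond the scatter)). No measurement shown explains why one extra carbon has so large an effect. Going by these compounds, whether a longer chain would lower the number further stays open, as does whether a carboxylic acid or a hydroxyl group at the chain end could replace the amine.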